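The compounds below may be only part of what the source reports. "The series", "measured", "known", "first", "only" and "open" are said of these compounds alone.

Of the compounds shown here, two of a shared core have so far been measured in a functional assay on B16-F10 cells (Mus musculus) for inhibition, read by MTT assay, with a stated time of 48 h; a lower number here means a stronger inhibitor, a higher number a weaker inhibitor. Compound 1 `COc1ccccc1/C=C/C(=O)Nc1ccc2ncnc(Nc3cccc(Br)c3)c2c1` gives 1.28 ug/mL in this assay. Compound 2 `O=C(/C=C/c1ccc(Cl)cc1)Nc1ccc2ncnc(Nc3cccc(Cl)c3)c2c1` gives 9.97 ug/mL in this assay, the higher of the two numbers, and its gap to compound 1 lies beyond the scatter. Compound 3 `O=C(/C=C/c1ccc([N+](=O)[O-])cc1)Nc1ccc2ncnc(Nc3cccc(Cl)c3)c2c1` has not yet been measured in this assay. It differs from compound 2 in one place: nitro in place of chloro on an aromatic carbon, the same change read one bond further out being 4-chlorophenyl to 4-nitrophenyl. Among the measured compounds shown here, no step of this kind stands among the measured compounds, so nothing in them shows which way it goes. Compound 3 is expected to sit near compound 2, with the step of a 1.4-fold lower number from compound 2 to compound 3 (0.15 log units; within the scatter) estimated to stay within the scatter. Compound 3 is estimated to give 7 ug/mL in this assay, within a range from 2.5 ug/mL to 20 ug/mL.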

Compound 3, half-maximal inhibitory concentration: 2.05 ug/mL
The estimate for compound 3 lay 3.4-fold (0.53 log units) above the measured number; measured number outside the range, below it.
By their numbers in this assay, from the lowest: compounds 1 and 3 (each within the scatter of the next); then compound 2.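

Exchanging chloro for nitro on this aromatic carbon, para to a large group, gives a 4.9-fold lower number from compound 2 to compound 3 (0.69 log units; beyond the scatter) in this assay, the first step among these compounds to isolate a single change. It shows that the number responds to what this position carries, which the earlier pair, differing in more than one place, could not show. Nitro brings 3 heavy atoms and 2 hydrogen-bond acceptors where chloro brings 1 heavy atom and no hydrogen-bond acceptor, but nothing available here tells which of these differences matters or explains the step.

Going by these compounds, it remains open whether an amine or a carboxylic acid on the same carbon would give a number nearer that of compound 2 or compound 3. This single step also leaves open whether the exchange would keep its size with a different group elsewhere on the shared core.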